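Halogen Swap on the Aryl Ring of a Shared Core

The source may hold more compounds than are shown below. What is called first, only, known or untested is meant among the compounds shown, and "the series" means these compounds.

Of the compounds shown here, three built on one shared core have been measured in a functional assay on MCF7 cells (Homo sapiens) for antiproliferative activity, read by MTT assay, with a stated time of 72 h; on this read-out lower numbers stand for stronger inhibition and higher numbers for weaker inhibition. Compound 1 `COc1ccc(/C=C2/CN(C)/C(=N/c3ccc(F)cc3)S2)cc1` gives 8000 nM. Compound 2 `COc1ccc(/C=C2/CN(C)/C(=N/c3ccc(C(C)(C)C)cc3)S2)cc1` gives 28700 nM, and compound 3 `COc1ccc(/C=C2/CN(C)/C(=N/c3ccc(C(F)(F)F)cc3)S2)cc1` gives 24100 nM. Among these three numbers compound 3 holds the second highest position: its nearest neighbour is compound 2, and the two lie within the scatter of each other, whereas compound 1 sits further off with a lower number. The step of a 3.0-fold higher number from compound 1 to compound 3 (0.48 log units; beyond the scatter) was beyond the scatter, as was a 3.6-fold higher number from compound 1 to compound 2 (0.55 log units; beyond the scatter); by contrast a 1.2-fold lower number from compound 2 to compound 3 (0.08 log units; within the scatter) stayed within it.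

Compound 4 `COc1ccc(/C=C2/CN(C)/C(=N/c3ccc(Br)cc3)S2)cc1` differs from compound 3 in one place: bromo in place of trifluoromethyl on an aromatic carbon. For the measured compounds named here, of the measured steps, the one from the fluoro compound to the trifluoromethyl compound bears most directly, since it exchanges one substituent on the same aromatic carbon for another, while the pair of compound 2 and compound 3 shows that tert-butyl and trifluoromethyl give much the same number. Bromo is a halogen, as fluoro is, so a partial return toward the lower number of compound 1 is expected, though not the full distance. The expected step is a 1.9-fold lower number from compound 3 to compound 4 (0.27 log units; within the scatter). Compound 4 is therefore estimated at 13000 nM, with a range from 6000 nM to 28000 nM.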

Compound 4, half-maximal inhibitory concentration: 7400 nM
Estimate against measurement, compound 4: 1.8-fold (0.24 log units) above, within the range that was stated.
By their numbers in this assay, from the lowest: compounds 4 and 1 (each within the scatter of the next); then compounds 3 and 2 (each within the scatter of the next).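

For the compounds shown here, with bromo on this aromatic carbon, this assay shows a 3.3-fold lower number from compound 3 to compound 4 (0.51 log units; beyond the scatter) and a 3.9-fold lower number from compound 2 to compound 4 (0.59 log units; beyond the scatter), both beyond the scatter, so the separation from trifluoromethyl and tert-butyl that the earlier compounds showed only for fluoro now appears with a second halogen. Fluoro and bromo cannot be told apart at this position, since a 1.1-fold lower number from compound 1 to compound 4 (0.03 log units; within the scatter) stays within the scatter, and the four compounds therefore fall into two pairs rather than a graded series. Trifluoromethyl carries fluorine yet sits with tert-butyl and not with fluoro, so within these four compounds the presence of fluorine alone does not place a substituent in the pair with the lower numbers, and the exchange of trifluoromethyl for bromo matters here even though neither group has a ring, a hydrogen-bond donor or acceptor, or a net charge.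

No measurement is available that explains why the substituents divide in this way. Going by these compounds, it remains open whether chloro, an amine, a carboxylic acid or a longer chain on this aromatic carbon would join the fluoro and bromo pair, the tert-butyl and trifluoromethyl pair, or neither.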